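Cytotoxicity limits on a thymidine-derived urea series

The source may hold more compounds than are shown below. What is called first, only, known or untested is meant among the compounds shown, and "the series" means these compounds.

The study looks at an ADME assay on MRC5 cells (Homo sapiens) for cytotoxicity (a higher number here means that more compound is tolerated, a lower number that less compound is tolerated), across a small set of nucleoside ureas and thioureas built on the shared core of compound 1 `Cc1cn([C@@H]2C[C@H](O)[C@@H](CNC(=O)Nc3ccc(C(C)(C)C)cc3)O2)c(=O)[nH]c1=O`. For compound 1 the assay reports only a limit, > 50000 nM, and not a number. Compound 2 `Cc1cn([C@@H]2C[C@H](O)[C@@H](CNC(=S)Nc3ccc(Cl)c(C(F)(F)F)c3)O2)c(=O)[nH]c1=O` carries a thiourea in place of the urea and a different aryl group. For compound 2 the read-out in this assay is likewise a limit, > 50000 nM. Among the compounds with values here, both measured values therefore sit at the limit of the assay (the limit of > 50000 nM in this assay, at which 2 of the 2 values shown sit), so no measured step between compounds can be given. Compound 3 `Cc1cn([C@@H]2C[C@H](O)[C@@H](CNC(=O)Nc3ccc(OCc4ccc(Cl)cc4)cc3)O2)c(=O)[nH]c1=O` has yet to be tested. It differs from compound 1 by (4-chlorobenzyl)oxy in place of tert-butyl on an aromatic carbon, on an aromatic carbon para to a large group. Since nothing measured separates the two known compounds, the step that the limit leaves unreadable from compound 1 to compound 3 is expected to be none beyond the scatter. Compound 3 is expected to give about 60000 nM, in the range 20000 nM to 200000 nM.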

Compound 3, half-maximal cytotoxic concentration: > 50000 nM
Compound 3: only a limit was reported (the forecaster's own chance of this, stated with the estimate: 75%); the middle value lies beyond the limit too.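

In this assay, within the data shown here, compound 3 again gives only a limit, so no step from compound 1 to compound 3 can be read: the limit of > 50000 nM in this assay, at which 3 of the 3 values shown sit. The compounds shown leave open whether (4-chlorobenzyl)oxy in place of tert-butyl changes how much compound is tolerated, and at what concentration any of them becomes cytotoxic.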